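The source may report more compounds than this note shows. Statements on the series, on what has been measured and on what is new or still open speak of the compounds shown alone.

Working notes on the series. All three measured compounds carry the core of compound 1 `C=CC1=C(C(=O)Nc2ccccc2OC)C(c2ccc(F)cc2)OC1`, and in a functional assay on QGY7701 cells (Homo sapiens) for cytotoxicity, read by MTT assay, with a stated time of 24 h (a lower number here means a stronger inhibitor, a higher number a weaker inhibitor), compound 1 gives 52800 nM. Compound 2 `C=CC1=C(C(=O)Nc2ccccc2)C(c2ccc(F)cc2)OC1` gives 46700 nM in this assay; the step of a 1.1-fold lower number from compound 1 to compound 2 (0.05 log units; within the scatter) lies within the scatter. Compound 3 `C=CC1=C(C(=O)NCCC)C(c2ccc(F)cc2)OC1` reaches only the limit of this assay, > 100000 nM, and so stands not as a number but as a limit (the limit of > 100000 nM in this assay, at which 1 of the 3 values shown sits). The steps into compound 3 read an at least 1.8-fold higher number from compound 1 to compound 3 (0.27 log units; that floor lies within the scatter) and an at least 2.1-fold higher number from compound 2 to compound 3 (0.33 log units; beyond the scatter), the second beyond the scatter.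

The next step leaves the amide altogether: compound 4 `C=CC1=C(C(=O)O)C(c2ccc(F)cc2)OC1` differs from compound 3 by hydroxy in place of propylamino on a carbonyl carbon. For the measured compounds named here, none of the measured steps concerns this change; they describe hydrogen in place of methoxy on an aromatic carbon and propyl in place of an aryl group on the amide-type nitrogen. No direction is therefore indicated for this assay, and the number is expected to stay at or near the limit already seen for compound 3. Compound 4 is estimated at 150000 nM, with a range of 60000 nM to 400000 nM, meaning an expected step that the limit leaves unreadable from compound 3 to compound 4.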

Compound 4, half-maximal inhibitory concentration: > 100000 nM
Compound 4 was reported as a limit (the forecaster's own chance of this, stated with the estimate: 70%); the middle value does not contradict the limit.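

In this assay compound 4 gives > 100000 nM, which is a limit and not a number. On the carbonyl carbon, hydroxy in place of anilino gives an at least 2.1-fold higher number from compound 2 to compound 4 (0.33 log units; beyond the scatter), so this second replacement of the anilino group, like propylamino before it, leaves the series without a readable number. Among the compounds shown, only the two with an aryl group on the amide nitrogen, compound 1 and compound 2, give numbers, and neither compound goes against this, while the propylamino and hydroxy compounds both sit at the ceiling: the limit of > 100000 nM in this assay, at which 2 of the 4 values shown sit.

Going by these compounds, the step between compound 3 and compound 4 cannot be read, so the order of propylcarbamoyl and carboxy stays open. Also open, on these data alone, is whether a methyl ester or a benzylamide on the same carbonyl carbon would give a number.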